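Swapping the aryl group on the amine of a shared core

The source may hold more compounds than are shown below. What is called first, only, known or untested is meant among the compounds shown, and "the series" means these compounds.

Compound 1 `CCCc1ccc(NC2=CC(=O)c3nc4n(c3C2=O)[C@H]2OC[C@@H](O)[C@H]2OC4)cc1` gives 4990 nM in a functional assay on HeLa cells (Homo sapiens) for inhibition, read by sulforhodamine B assay; a lower number here means a stronger inhibitor, a higher number a weaker inhibitor. Compound 2 `O=C1C=C(NCc2ccccc2)C(=O)c2c1nc1n2[C@H]2OC[C@@H](O)[C@H]2OC1` reaches only the limit of > 8000 nM in this assay, so no number is known for it. Compound 3 `COc1ccccc1NC1=CC(=O)c2nc3n(c2C1=O)[C@H]1OC[C@@H](O)[C@H]1OC3` gives 2950 nM in this assay.

Among the two numbers in hand, compound 3 has the lowest, and its nearest neighbour is compound 1: the step of a 1.7-fold lower number from compound 1 to compound 3 (0.23 log units; within the scatter) is within the usual scatter, so the two cannot be ranked. The step of an at least 2.7-fold lower number from compound 2 to compound 3 (0.43 log units; beyond the scatter) is beyond the scatter, but it rests on a limit of > 8000 nM in this assay, at which 1 of the 3 values shown sits, rather than on a number.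

Compound 4 `O=C1C=C(Nc2ccc(C(F)(F)F)cc2)C(=O)c2c1nc1n2[C@H]2OC[C@@H](O)[C@H]2OC1` differs from compound 3 in one place: 4-(trifluoromethyl)phenyl in place of 2-methoxyphenyl on an amine nitrogen. Both compound 1 and compound 4 carry a group in the 4-position of the phenyl ring on the amine nitrogen, and the step from compound 1 to compound 3 shows that such a change stayed within the scatter. Only compound 2, with benzyl, falls clearly away. The step of a 1.4-fold higher number from compound 3 to compound 4 (0.13 log units; within the scatter) is therefore expected to stay within the scatter of this assay. Compound 4 is estimated at 4000 nM in this assay, with a range from 1500 nM to 12000 nM.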

Compound 4, half-maximal inhibitory concentration: > 8000 nM
Compound 4: no number, only a limit; the forecaster's own chance of this, stated with the estimate: 20%; middle value at least 2.0-fold (0.30 log units) away from the limit.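

In this assay, compound 4 reaches only a limit, so its steps give floors and not sizes. Even so, an at least 2.7-fold higher number from compound 3 to compound 4 (0.43 log units; beyond the scatter) is the first step beyond the scatter between two compounds with a phenyl ring directly on the amine nitrogen, which shows that a directly attached phenyl ring does not by itself keep a compound clear of the limit. The comparison that changes only the group on the ring, an at least 1.6-fold higher number from compound 1 to compound 4 (0.20 log units; that floor lies within the scatter), is weaker evidence, and it cannot yet separate trifluoromethyl from propyl; the step between compound 2 and compound 4 cannot be read at all, and the limit now holds more of the series: the limit of > 8000 nM in this assay, at which 2 of the 4 values shown sit.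

As far as these compounds go, the step from compound 3 to compound 4 changes both the group on the ring and where it sits, so it remains open whether the group or its place matters more, and 4-methoxyphenyl on the same nitrogen would separate the two. Also open, from the compounds shown here alone, is how a phenyl ring carrying an amine, a carboxylic acid or a longer chain than propyl would read in this assay.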